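A few compounds are considered here, and "the series" means these few. Any claim that something is new, unique, unknown or untested is made for them only; others in the source may bear on it.

For the measured compounds named here, compound 1 `COc1ccccc1-c1cc(=O)[nH]n1-c1ccc(C(=O)NNC(=O)CO[N+](=O)[O-])cc1` gives in a functional assay on the whole organism (strain Wistar) for inhibition, with Rattus norvegicus as the target, read by paw edema, with a stated time of 1 h, at a dose of 6 mg/kg by the oral route (a lower number here means less inhibition, a higher number more inhibition at the dose given (going by the name of the read-out)), a reading of 55.1%, and compound 2 `O=C(CO[N+](=O)[O-])NNC(=O)c1ccc(-n2[nH]c(=O)cc2-c2ccc(Cl)cc2)cc1` in this assay gives 5.88%, the lower of the two numbers known, with the only other number, that of compound 1, standing beyond the scatter above it. The step of a number 49.2 percentage points lower from compound 1 to compound 2 (beyond the scatter) accompanies the exchange of 4-chlorophenyl for 2-methoxyphenyl. Compound 3 `O=C(CO[N+](=O)[O-])NNC(=O)c1ccc(-n2[nH]c(=O)cc2-c2ccccc2)cc1` differs from compound 2 by hydrogen in place of chloro on an aromatic carbon. Going by the values given here, no measured step removes a chloro alone, so the only guide is that compound 2 sits low while compound 1 sits high. Compound 3 is therefore expected to move by a number 14.1 percentage points higher from compound 2 to compound 3 (beyond the scatter), toward a middling number. The estimate for compound 3 is 20%, within 3% to 45%.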

Compound 3, a percentage reported as inhibition, in the whole organism at one dose (the size of the read-out at that dose, not a potency): 19.8%
Estimate against measurement, compound 3: 0.2 percentage points above, within the range that was stated.
By their numbers in this assay, from the lowest: compound 2; then compound 3; then compound 1.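

In this assay, a number 13.9 percentage points higher from compound 2 to compound 3 (beyond the scatter) shows that the chloro, para to a large group, goes with lower inhibition than hydrogen in this series. The other new comparison, a number 35.3 percentage points lower from compound 1 to compound 3 (beyond the scatter), places phenyl between the two substituted compounds and shows that the methoxy of the 2-methoxyphenyl accounts for the larger gain.

Going by these compounds, it remains open whether a methoxy para to a large group would match compound 1 or fall toward compound 2, and how an amine or a carboxylic acid at that carbon would compare with compound 3. Nothing available bears on why either step occurs.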